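A few compounds are considered here, and "the series" means these few. Any claim that something is new, unique, unknown or untested is made for them only; others in the source may bear on it.

Compound 1 `Cc1ccc(NC(=O)Nc2cccc(CNc3nccnc3Cl)c2)cc1C`: in a functional assay on MGC-803 cells (Homo sapiens) for antiproliferative activity, read by MTT assay, with a stated time of 48 h (on this read-out lower numbers stand for stronger inhibition and higher numbers for weaker inhibition), compound 1 gives 9870 nM. Compound 2 `O=C(Nc1cccc(CNc2nccnc2Cl)c1)NC1CCCCC1`: compound 2 gives > 40000 nM, which is a limit of the assay rather than a number (the limit of > 40000 nM in this assay, at which 1 of the 3 values shown sits). Compound 3 `O=C(Nc1cccc(CNc2nccnc2Cl)c1)Nc1ccc(Cl)cc1Cl`: compound 3 gives 6430 nM.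

On these numbers compound 3 has the lowest value; its nearest neighbour is compound 1, and the step of a 1.5-fold lower number from compound 1 to compound 3 (0.19 log units; within the scatter) lies within the scatter. Compound 4 `CN(C)c1ccc(NC(=O)Nc2cccc(CNc3nccnc3Cl)c2)cc1` differs from compound 3 in one place: 4-(dimethylamino)phenyl in place of 2,4-dichlorophenyl on an amide-type nitrogen. Going by the values given here, the one comparable change, one aryl group for another on the same nitrogen, is a 1.5-fold lower number from compound 1 to compound 3 (0.19 log units; within the scatter), within the scatter; the larger steps of an at least 4.0-fold higher number from compound 1 to compound 2 (0.60 log units; beyond the scatter) and an at least 6.2-fold lower number from compound 2 to compound 3 (0.79 log units; beyond the scatter) involve cyclohexyl and so bear less directly. A step of a 1.4-fold higher number from compound 3 to compound 4 (0.15 log units; within the scatter) within the scatter is therefore expected. Compound 4 is estimated at 9000 nM, within 4000 nM to 25000 nM.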

Compound 4, half-maximal inhibitory concentration: 11500 nM
Compound 4: the middle estimate sits 1.3-fold (0.11 log units) below what was measured, and the stated range covers the measured number.
By their numbers in this assay, from the lowest: compounds 3, 1 and 4 (each within the scatter of the next). At a limit, above all of these: compound 2.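

With 4-(dimethylamino)phenyl, a third aryl group on the amide-type nitrogen and the first to bring a nitrogen there, the number stays within the scatter of the other two aryl compounds: a 1.8-fold higher number from compound 3 to compound 4 (0.25 log units; within the scatter) and a 1.2-fold higher number from compound 1 to compound 4 (0.07 log units; within the scatter). The step from cyclohexyl, an at least 3.4-fold lower number from compound 2 to compound 4 (0.54 log units; beyond the scatter), lies beyond the scatter, as it does for the other two aryl groups. The value of compound 2 is a limit and not a number: the limit of > 40000 nM in this assay, at which 1 of the 4 values shown sits.

On these data alone, whether a carboxylic acid or a morpholine on this phenyl ring, or a pyridine in its place, would move the number remains open. So does the contribution of the shared core, which is the same in all four compounds.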